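A few compounds are considered here, and "the series" means these few. Any claim that something is new, unique, unknown or untested is made for them only; others in the source may bear on it.

Measured in a functional assay on the whole organism (strain Kunming) for inhibition, with Mus musculus as the target, in the writhing test, at a dose of 40 mg/kg by the oral route; on this read-out lower numbers stand for less inhibition and higher numbers for more inhibition at the one dose given (going by the name of the read-out):
compound 1, `CC(=O)Oc1ccc(-c2ccc(F)cc2F)cc1C(=O)Nc1cccc(C)c1`, 19%;
compound 2, `CC(=O)Oc1ccc(-c2ccc(F)cc2F)cc1C(=O)Nc1cc(C)ccc1C`, 13.2%;
compound 3, `O=C(Oc1ccc(-c2ccc(F)cc2F)cc1C(=O)Nc1ccccc1)c1ccccc1`, 5.57%.

Between compound 1 and compound 2 the change is methyl in place of hydrogen on an aromatic carbon, and it gave a number 5.8 percentage points lower from compound 1 to compound 2 (within the scatter). Compound 3 has a different core from compound 1; the difference between the two cores is not broken down here. Compound 4, `Cc1ccccc1NC(=O)c1cc(-c2ccc(F)cc2F)ccc1OC(=O)c1ccccc1`, is not yet measured; it differs from compound 3 by methyl in place of hydrogen on an aromatic carbon. Among the measured compounds shown here, this is the same kind of change as the one from compound 1 to compound 2, though there the place was also para to a methyl group, which it is not here. Since the earlier step was a number 5.8 percentage points lower from compound 1 to compound 2 (within the scatter), a step of similar size is expected here, a number 1.6 percentage points lower from compound 3 to compound 4 (within the scatter). Compound 4 is therefore expected to give about 4%, between 0% and 13%.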

Compound 4, a percentage reported as inhibition, in the whole organism at one dose (the size of the read-out at that dose, not a potency): 20.8%
Estimate against measurement, compound 4: 16.8 percentage points below; the measured number lies above the stated range.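

Turning phenyl into 2-methylphenyl gave a number 15.2 percentage points higher from compound 3 to compound 4 (beyond the scatter) in this assay. The same kind of change did not keep its size or direction from one core to the other: the same change on two cores in this assay, a number 5.8 percentage points lower (within the scatter) from compound 1 to compound 2 and a number 15.2 percentage points higher (beyond the scatter) from compound 3 to compound 4, 21 percentage points apart, beyond the scatter of two such steps. Among the compounds shown here, this shows that, in this series, a step seen on one core is a poor guide to the step on another, but it rests on only two pairs, the methyl's surroundings on the ring also differ between them, and it does not show why the steps differ.

Going by these compounds, it remains open whether a larger group at the same place, such as ethyl or methoxy, would follow methyl on the core of compound 3. On these data alone, each number also comes from one dose, so potency remains open too.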